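The compounds below may be only part of what the source reports. "The series", "measured", "known", "first", "only" and "open" are said of these compounds alone.

Compound 2 `Cc1nn(C)c(Oc2cccc(F)c2F)c1/C=N\CCCCCCOc1cc2oc(=O)cc(C)c2cc1Cl` and compound 1 `Cc1nn(C)c(Oc2ccc(Cl)cc2)c1/C=N\CCCCCOc1cc2oc(=O)cc(C)c2cc1Cl` have both been tested in a functional assay on SMMC-7721 cells (Homo sapiens) for antiproliferative activity, read by MTT assay, with a stated time of 72 h; a higher number here means a weaker inhibitor, a lower number a stronger inhibitor. Compound 2 gives 22800 nM, and compound 1 gives 17500 nM; the two numbers lie within the scatter of each other. Compound 3 `Cc1nn(C)c(Oc2ccc(Cl)cc2)c1/C=N\CCCCCCOc1cc2oc(=O)cc(C)c2cc1Cl` is compound 2 with 4-chlorophenyl in place of 2,3-difluorophenyl on an oxygen on an aromatic ring. Going by the values given here, with no measured step of this kind available, compound 3 is expected to differ from compound 2 by no more than the scatter, so a step of a 1.3-fold lower number from compound 2 to compound 3 (0.10 log units; within the scatter) is estimated. Compound 3 is therefore expected to give 18000 nM, within 9000 nM to 36000 nM, because compound 1 carrying the same 4-chlorophenyl gives 17500 nM.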

Compound 3, half-maximal inhibitory concentration: 2080 nM
Beside the measured number, compound 3's estimate is 8.7-fold (0.94 log units) above it, and the stated range ends above it.
By their numbers in this assay, from the lowest: compound 3; then compounds 1 and 2 (each within the scatter of the next).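

In this assay, the group on this oxygen clearly matters: 4-chlorophenyl in place of 2,3-difluorophenyl gives an 11-fold lower number from compound 2 to compound 3 (1.04 log units; beyond the scatter), a large step that the earlier pair, differing in two places, could not isolate. Compound 1 carries the same 4-chlorophenyl on a different chain and gives 17500 nM, so the low number of compound 3 does not follow from this group alone. Nothing measured here explains the step. Plain phenyl or 4-fluorophenyl on this oxygen could show whether chlorine itself matters, and a longer chain could show how far the chain effect extends.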